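This account rests on a few compounds, and the source may have more. Where it says the series, first, only, none or still open, it means among the compounds named here.

Of the compounds shown here, three have so far been measured in an assay on A7R5 cells for displacement of a labelled ligand from Endothelin-1 receptor (Rattus norvegicus); on this read-out lower numbers stand for stronger inhibition and higher numbers for weaker inhibition. Compound 1 `Cc1onc(NS(=O)(=O)c2ccc(N)cc2)c1I` gives 11000 nM. Compound 2 `COc1cccc(Sc2c(NS(=O)(=O)c3ccc(C(C)(C)C)cc3)noc2CCCC#N)c1` gives 1300 nM, and compound 3 `COc1cccc(Sc2c(NS(=O)(=O)c3ccc(C(C)(C)C)cc3)noc2CCCCC=O)c1` gives 1400 nM. Compound 2 has the lowest of the three numbers; its nearest neighbour is compound 3, and the step of a 1.1-fold higher number from compound 2 to compound 3 (0.03 log units; within the scatter) lies within the scatter, so the two cannot be told apart on these data. Compound 1 stands furthest away, with a number beyond the scatter above that of compound 2.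

Compound 4 `COc1cccc(Sc2c(NS(=O)(=O)c3ccc(C(C)(C)C)cc3)noc2CCC/C=N/O)c1` is the unmeasured compound. Compared with compound 2 it carries a group of 3 heavy atoms (1 carbon, 1 nitrogen, 1 oxygen; no ring) in place of a group of 2 heavy atoms (1 carbon, 1 nitrogen; no ring), on a saturated chain carbon, three bonds along the chain from an aromatic carbon. Among the measured compounds shown here, the one measured step that bears on this place in the molecule is the one from compound 2 to compound 3, a 1.1-fold higher number from compound 2 to compound 3 (0.03 log units; within the scatter), in which cyano gave way to formylmethyl and the number hardly moved. The group that enters compound 4 is again a small uncharged chain end, differing from both cyano and formylmethyl in what is counted for it. For the measured compounds named here, with only one step known at this position, and that within the scatter, no shift beyond the scatter is expected in this assay. Compound 4 is therefore estimated at 1300 nM, with a range from 600 nM to 2800 nM, which means an expected step of no change at the digits printed from compound 2 to compound 4 (within the scatter) that stays within the scatter.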

Compound 4, half-maximal inhibitory concentration: 1500 nM
Estimate against measurement, compound 4: 1.2-fold (0.06 log units) below, within the range that was stated.
By their numbers in this assay, from the lowest: compounds 2, 3 and 4 (each within the scatter of the next); then compound 1.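

In this assay, the step of a 1.2-fold higher number from compound 2 to compound 4 (0.06 log units; within the scatter) lies within the scatter, even though the entering group carries 1 hydrogen-bond donor and cyano carries 0. Among the compounds shown here, the step of a 1.1-fold higher number from compound 3 to compound 4 (0.03 log units; within the scatter) also lies within the scatter, so this position now offers three different chain ends, on a saturated chain carbon, three bonds along the chain from an aromatic carbon, that cannot be told apart on these numbers, where the earlier compounds offered only two. What lies behind this flat result cannot be said, as no measurement here addresses it.

Going by these compounds, all three chain ends are small and uncharged as counted, so it remains open whether a carboxylic acid, an amine, a ring or a much longer chain at the same place would also leave the number where it is. On these data alone, it is also open whether the same tolerance would hold in the other assays or on a different core, since all three of these groups have been read in this one assay and on one shared core.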